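The source may hold more compounds than are shown below. What is called first, only, known or untested is meant among the compounds shown, and "the series" means these compounds.

Notes on the series. Compound 3 `CCCc1cc(N2CCCC2)c2cc(NC(=O)/C=C/c3ccc(C(F)(F)F)cc3)ccc2n1` carries pyrrolidin-1-yl on the shared core and a trifluoromethyl-bearing phenyl on the double-bonded chain; in an assay on isolated protein for displacement of a labelled ligand from melanin-concentrating hormone receptor 1 (Homo sapiens) (a higher number here means a weaker inhibitor, a lower number a stronger inhibitor), compound 3 gives 17 nM. Compound 1 `CCCc1cc(N2CCCCC2)c2cc(NC(=O)/C=C/c3ccc(C(F)(F)F)cc3)ccc2n1` differs from it only at the amine on the core. In this assay compound 1 reaches only a limit, > 4000 nM, which is not a number. The move between the two is read as an at least 230-fold lower number from compound 1 to compound 3 (2.37 log units; beyond the scatter), with the reservation that it rests on (the limit of > 4000 nM in this assay, at which 1 of the 3 values shown sits). Compound 2 `CCCc1cc(N)c2cc(NC(=O)/C=C/c3ccc(O)cc3)ccc2n1` has a free amine on the core and 4-hydroxyphenyl on the chain; in this assay compound 2 gives 1100 nM, the highest of the two values that are numbers, the nearest being compound 3 well below it.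

Compound 4 `CCCc1cc(N)c2cc(NC(=O)/C=C/c3cccc(Cl)c3)ccc2n1` is compound 2 with the aryl group exchanged: 3-chlorophenyl in place of 4-hydroxyphenyl on a double-bonded chain carbon bound to a double-bonded chain carbon. Going by the values given here, no measured step alters this aryl group; the single step measured, from compound 1 to compound 3, concerns the amine on the core and so does not bear on it. Compound 2 and compound 3 differ in both places at once, so their gap cannot be split. The step is therefore expected to be small and of uncertain direction, a 1.8-fold lower number from compound 2 to compound 4 (0.26 log units; within the scatter). Compound 4 is expected near 600 nM, within 120 nM to 3000 nM.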

Compound 4, half-maximal inhibitory concentration: 1100 nM
Estimate against measurement, compound 4: 1.8-fold (0.26 log units) below, within the range that was stated.
By their numbers in this assay, from the lowest: compound 3; then compounds 2 and 4 (each within the scatter of the next). At a limit, above all of these: compound 1.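

Going by these compounds alone, with a free amine on the core, the first measured change of the aryl group on a double-bonded chain carbon bound to a double-bonded chain carbon gives, in this assay, no change at the digits printed from compound 2 to compound 4 (within the scatter). At this position and in this setting, the number therefore stays in place when 3-chlorophenyl, which has no hydrogen-bond donor or acceptor, takes the place of 4-hydroxyphenyl, which has one of each, and chlorine replaces oxygen in the entering group. Nothing measured here bears on why the number holds through this exchange.

From the compounds shown here alone, compound 2 and compound 4 both carry the free amine, and compound 3 differs from each of them in two places, so those gaps cannot be read as steps and it remains open whether 3-chlorophenyl and 4-hydroxyphenyl would also stay level with pyrrolidin-1-yl on the core. Also open, going by these compounds, is how a phenyl carrying a carboxylic acid or a nitrile on the chain, or an azetidine or a dimethylamine on the core, would read in this assay.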